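The compounds below may be only part of what the source reports. "The series", "measured", "known", "first", "only" and "open" are said of these compounds alone.

Measured in a functional assay on MCF7 cells (Homo sapiens) for inhibition, read by CCK-8 assay, with a stated time of 48 h; on this read-out higher numbers stand for weaker inhibition and lower numbers for stronger inhibition:
- compound 1 `COc1cc(-c2ccnc3cc(-c4ccc5c(ccn5C)c4)nn23)cc(OC)c1OC`: 3 nM
- compound 2 `COc1cc(-c2ccnc3cc(-c4cccc(C)c4)nn23)cc(OC)c1OC`: 1080 nM

Compound 2 holds the higher of the two numbers. Compound 3 `COc1cc(-c2ccnc3cc(-c4ccc(C(C)=O)cc4)nn23)cc(OC)c1OC` differs from it as follows: 4-acetylphenyl in place of 3-methylphenyl on an aromatic carbon. Among the compounds with values here, the only measured step bearing on this change is the large one at the same place, a 360-fold higher number from compound 1 to compound 2 (2.56 log units; beyond the scatter). Neither compound 2 nor compound 3 carries 1-methyl-1H-indol-5-yl, so no return towards compound 1 is expected, and no shift beyond the scatter is expected in this assay. The expected step is a 1.4-fold higher number from compound 2 to compound 3 (0.14 log units; within the scatter). Compound 3 is estimated at 1500 nM, with an expected range of 300 nM to 8000 nM.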

Compound 3, half-maximal inhibitory concentration: 5230 nM
Compound 3: the middle estimate sits 3.5-fold (0.54 log units) below what was measured; the range from low to high includes it.
By their numbers in this assay, from the lowest: compound 1; then compound 2; then compound 3.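

In this assay, 4-acetylphenyl at this aromatic carbon gives a 4.8-fold higher number from compound 2 to compound 3 (0.69 log units; beyond the scatter), so adding a hydrogen-bond acceptor to the phenyl ring brings no recovery towards compound 1. The gap to the 1-methyl-1H-indol-5-yl group widens to a 1700-fold higher number from compound 1 to compound 3 (3.24 log units; beyond the scatter), and the two phenyl groups shown both stay far from it. No available evidence accounts for either step.

The effect of the acetyl group remains unseparated from that of its place on the phenyl ring. As far as these compounds go, how an amine or a carboxylic acid on that ring would read also remains open.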